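A few compounds are considered here, and "the series" means these few. Any claim that something is new, unique, unknown or untested is made for them only; others in the source may bear on it.

Of the compounds shown here, two have been measured in a functional assay on CHO-K1 cells with Glucose-dependent insulinotropic receptor (Homo sapiens) as the target, read by a luciferase reporter, with a stated time of 5 h; a lower number here means a smaller maximal response, a higher number a larger maximal response. Compound 1 `CC(C)c1noc(N2CCC(O)CC2)n1` gives 105%. Compound 2 `CC(C)OC(=O)N1CCC(Oc2ncnc3c2CCN3c2ccc(S(C)(=O)=O)nc2)CC1` gives 97%, a number that sits within the scatter of compound 1, so the two cannot be told apart on these results. Compound 3 `Cc1cc(S(C)(=O)=O)ccc1N1CCc2c(OC3CCN(C(=O)OC(C)C)CC3)ncnc21` has not yet been measured; it differs from compound 2 in one place: 2-methyl-4-(methylsulfonyl)phenyl in place of 6-(methylsulfonyl)pyridin-3-yl on a nitrogen on an aromatic ring in a ring. Going by the values given here, no measured pair shows the effect of such a change, so no step beyond the scatter is expected in this assay in either direction. For compound 3 a largest response of 95% is expected, between 80% and 110%. This means an expected step of a number 2 percentage points lower from compound 2 to compound 3 (within the scatter).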

Compound 3, largest response reached (reported as percent of maximum), in percent of the reference or control that the assay uses: 80%
The estimate for compound 3 lay 15 percentage points above the measured number; the range from low to high includes it.
By their numbers in this assay, from the lowest: compound 3; then compounds 2 and 1 (each within the scatter of the next).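

On a nitrogen on an aromatic ring in a ring, the choice of aryl group does matter: in this assay the new group gives a number 17 percentage points lower from compound 2 to compound 3 (beyond the scatter) and the maximal response falls measurably. The swap removes the ring nitrogen and adds a methyl at once, so the two changes arrive together. No available data give a reason for this step.

The compounds shown leave open which of the two changes carries the step, a question that 4-(methylsulfonyl)phenyl without the methyl would address. Going by these compounds, how an amine in place of the methylsulfonyl would behave also remains open.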